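This account rests on a few compounds, and the source may have more. Where it says the series, first, only, none or still open, it means among the compounds named here.

Working notes on the series. Compound 1 `COc1cc2c(Oc3ccc(NC(=O)c4nn(-c5ccccc5OC(F)(F)F)c(=O)cc4C)cc3F)ccnc2cc1OCCCN1CCCC1` in a functional assay on HT-29 cells (Homo sapiens) for inhibition, read by MTT assay, with a stated time of 72 h (a lower number here means a stronger inhibitor, a higher number a weaker inhibitor), gives 180 nM. Compound 2 `COc1cc2c(Oc3ccc(NC(=O)c4nn(-c5ccccc5OC(F)(F)F)c(=O)cc4C)cc3F)ccnc2cc1OCCCN1CCCCC1` in this assay gives 190 nM; the change between the two, (piperidin-1-yl in place of pyrrolidin-1-yl on a saturated chain carbon, three bonds along the chain from an oxygen on an aromatic ring), makes a step of a 1.1-fold higher number from compound 1 to compound 2 (0.02 log units; within the scatter). Compound 3 `COc1ccc(-n2nc(C(=O)Nc3ccc(Oc4ccnc5cc(OCCCN6CCCC6)c(OC)cc45)c(F)c3)c(C)cc2=O)cc1` differs from compound 1 on the core by 4-methoxyphenyl in place of 2-(trifluoromethoxy)phenyl on an aromatic nitrogen, and in this assay compound 3 gives 3300 nM, a step of an 18-fold higher number from compound 1 to compound 3 (1.26 log units; beyond the scatter), leaving it with the highest number of the three measured. Compound 4 `COc1ccc(-n2nc(C(=O)Nc3ccc(Oc4ccnc5cc(OCCCN6CCCCC6)c(OC)cc45)c(F)c3)c(C)cc2=O)cc1` is still to be measured; it differs from compound 3 by piperidin-1-yl in place of pyrrolidin-1-yl on a saturated chain carbon, three bonds along the chain from an oxygen on an aromatic ring, the same change, at the same place, that turns compound 1 into compound 2. Because that change gave only a 1.1-fold higher number from compound 1 to compound 2 (0.02 log units; within the scatter), the expected step here is a 1.1-fold higher number from compound 3 to compound 4 (0.03 log units; within the scatter). Compound 4 in this assay is therefore estimated at 3500 nM, with a plausible range from 1800 nM to 7000 nM.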

Compound 4, half-maximal inhibitory concentration: 3200 nM
Beside the measured number, compound 4's estimate is 1.1-fold (0.04 log units) above it; the measured number falls inside the stated range.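

In this assay, the change of piperidin-1-yl in place of pyrrolidin-1-yl carries from one core to the other, with a 1.0-fold lower number from compound 3 to compound 4 (0.01 log units; within the scatter) matching the earlier step: the same change on two cores in this assay, a 1.1-fold higher number (0.02 log units; within the scatter) from compound 1 to compound 2 and a 1.0-fold lower number (0.01 log units; within the scatter) from compound 3 to compound 4, 1.1-fold (0.04 log units) apart, within the scatter of two such steps

The change of 4-methoxyphenyl in place of 2-(trifluoromethoxy)phenyl on the aromatic nitrogen also carries over, with a 17-fold higher number from compound 2 to compound 4 (1.23 log units; beyond the scatter) matching its earlier step: the same change on two cores in this assay, an 18-fold higher number (1.26 log units; beyond the scatter) from compound 1 to compound 3 and a 17-fold higher number (1.23 log units; beyond the scatter) from compound 2 to compound 4, 1.1-fold (0.04 log units) apart, within the scatter of two such steps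

Across these four compounds the two changes therefore combine without interaction, but this does not show why either step has its size, nor that the result extends to other groups or other assays.

Still open, from the compounds shown here alone, is how a morpholin-4-yl or dimethylamino group would behave at the end of the chain. Also open, going by these compounds, is the effect of a 2-methoxyphenyl or unsubstituted phenyl group on the aromatic nitrogen.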